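Methoxy in Place of Hydrogen: Expectation for Compound 3

The compounds below may be only part of what the source reports. "The series", "measured", "known", "first", "only" and "open" are said of these compounds alone.

Compound 2 `O=C(CSC(=S)N[C@H]1CCOC1=O)Nc1ccccc1` shares its core with compound 1 `O=C(CSC(=S)N[C@H]1CCOC1=O)Nc1ccc(Cl)cc1` and differs from it at a single aromatic carbon. In a functional assay on MCF7 cells (Homo sapiens) for cytotoxicity, read by MTT assay, with a stated time of 72 h (a lower number here means a stronger inhibitor, a higher number a weaker inhibitor), compound 1 gives 50300 nM. In this assay compound 2 reaches only a limit of the assay, > 128000 nM, which is not a number; it is the point the limit of > 128000 nM in this assay, at which 1 of the 2 values shown sits, at which one of the two measured values sits. Among the compounds with values here, the single measured step, an at least 2.5-fold higher number from compound 1 to compound 2 (0.40 log units; beyond the scatter), places compound 2 at the weak end of what is known. Compound 3 `COc1ccc(NC(=O)CSC(=S)N[C@H]2CCOC2=O)cc1` is not yet measured; it differs from compound 2 by methoxy in place of hydrogen on an aromatic carbon. The step from compound 1 to compound 2 concerns the same aromatic carbon, where swapping chloro for hydrogen raised the number beyond the scatter; it shows that this position matters but says nothing about how methoxy behaves there. Because compound 2 already sits at the limit > 128000 nM in this assay, the expected step is an at least 1.1-fold lower number from compound 2 to compound 3 (0.06 log units; that floor lies within the scatter), with no confident direction. Compound 3 is therefore expected to give about 110000 nM in this assay, within a range from 40000 nM to 300000 nM.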

Compound 3, half-maximal inhibitory concentration: > 128000 nM
Compound 3: a limit, no number; the forecaster's own chance of this, stated with the estimate: 55%; middle value at least 1.1-fold (0.06 log units) from the limit.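

Placing methoxy on the aromatic carbon that carries chloro in compound 1 does not preserve the activity seen with chloro: in this assay, the change gives an at least 2.5-fold higher number from compound 1 to compound 3 (0.40 log units; beyond the scatter). Compound 1 had previously been compared only with the unsubstituted compound 2, so the earlier step could have meant that any group at this position would give a measurable value, but methoxy shows that this is not so. Among the three compounds, only the chloro compound gives a number in this assay, and the step from compound 2 to compound 3 cannot be read, as both compounds stand at the same limit of the assay: the limit of > 128000 nM in this assay, at which 2 of the 3 values shown sit.

On these data alone, how much activity, if any, compound 2 and compound 3 retain remains unknown, and so does any order between them. As far as these compounds go, it is also open whether chloro is unusual at this position or whether another group there, such as fluoro, bromo, trifluoromethyl or an amine, would also bring the value within the range of the assay.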